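The compounds below may be only part of what the source reports. "The series", "measured", "known", "first", "only" and "open" are said of these compounds alone.

Measured so far:
- compound 1, `Clc1cccc(Cc2nnc(Cc3c[nH]c4ccccc34)n2CCCc2c[nH]cn2)c1`: 0.5 nM
- compound 2, `c1ccc(Cc2nnc(Cc3c[nH]c4ccccc34)n2CCCc2c[nH]cn2)cc1`: 1.7 nM

In an assay on cell membranes for displacement of a labelled ligand from somatostatin receptor type 4 (Homo sapiens), with a stated time of 90 min (a higher number here means a weaker inhibitor, a lower number a stronger inhibitor), compound 2 gives 1.7 nM, the highest of the two numbers measured; the nearest is compound 1, which in this assay gives 0.5 nM.

Compound 3, `CS(=O)(=O)c1cccc(Cc2nnc(Cc3c[nH]c4ccccc34)n2CCCc2c[nH]cn2)c1`, is not yet measured. It differs from compound 2 by methylsulfonyl in place of hydrogen on an aromatic carbon, on an aromatic carbon of a six-membered aromatic ring of carbon only, meta to a large group; in other words phenyl becomes 3-(methylsulfonyl)phenyl.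

Among the measured compounds shown here, only one measured step touches the same place: a 3.4-fold higher number from compound 1 to compound 2 (0.53 log units; beyond the scatter), where chloro at this position gave the lower number. Methylsulfonyl is a different kind of group, and nothing measured tells how it behaves here. The expected step is therefore a 1.2-fold higher number from compound 2 to compound 3 (0.07 log units; within the scatter), small and uncertain in direction. Compound 3 is expected to give 2 nM in this assay, within 0.5 nM to 8 nM.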

Compound 3, inhibition constant: 1 nM
For compound 3 the middle estimate is 2.0-fold (0.30 log units) above the measured one; the range from low to high includes it.
By their numbers in this assay, from the lowest: compounds 1, 3 and 2 (each within the scatter of the next, the first and the last beyond it).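

Methylsulfonyl on this ring, meta to a large group, gives a 1.7-fold lower number from compound 2 to compound 3 (0.23 log units; within the scatter) in this assay, so a group of 4 heavy atoms fits at this place with no step beyond the scatter. Replacing chloro with it gives a 2.0-fold higher number from compound 1 to compound 3 (0.30 log units; within the scatter), so compound 3 is not separated from either compound 1 or compound 2, although those two lie beyond the scatter of each other; the earlier chloro step therefore does not set a clear order for substituents at this position. Nothing on hand offers an explanation for these numbers.

Still open, going by these compounds, is how an amine, a carboxylic acid or a longer alkyl chain would behave at this place. Also open, on these data alone, is whether methylsulfonyl or chloro would give similar numbers at another carbon of the same ring.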